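This account rests on a few compounds, and the source may have more. Where it says the series, first, only, none or still open, it means among the compounds named here.

In a functional assay on IMR-32 cells (Homo sapiens) for cytotoxicity, read by sulforhodamine B assay, with a stated time of 48 h (a lower number here means a stronger inhibitor, a higher number a weaker inhibitor), compound 1 (`O=C(c1cccnc1)c1cc(Cl)ccc1O`) gives 19500 nM, compound 2 (`C=CCOc1ccc(Br)cc1C(=O)c1cccnc1`) gives 88000 nM and compound 3 (`C=CCOc1ccc(C)cc1C(=O)c1cccnc1`) gives 87000 nM. Compound 3 therefore stands level with compound 2, and the number for compound 1 is clearly lower than either of them. Compound 4 (`C=CCOc1ccc(Cl)cc1C(=O)c1cccnc1`) has not yet been measured. It differs from compound 3 by a single swap on the ring that carries the allyloxy group: chloro in place of methyl on an aromatic carbon. In words, chloro replaces methyl on an aromatic carbon, para to that allyloxy group.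

Within the data shown here, one measured step bears directly on this change. Putting methyl in place of bromo on an aromatic carbon gave a 1.0-fold lower number from compound 2 to compound 3 (0.00 log units; within the scatter), so that exchange left the number where it was. Compound 1 also carries chloro, but it has no allyloxy group, so its value cannot show what chloro does alone. Among the measured compounds shown here, with only one relevant step, the evidence is thin, but it gives no reason to expect a real shift in this assay. The expected change is no change at the digits printed from compound 3 to compound 4 (within the scatter), which amounts to no step beyond the scatter. Compound 4 is estimated at about 87000 nM, with an expected range from 50000 nM to 150000 nM.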

Compound 4, half-maximal inhibitory concentration: 91000 nM
Compound 4: the middle estimate sits 1.0-fold (0.02 log units) below what was measured; the range from low to high includes it.
By their numbers in this assay, from the lowest: compound 1; then compounds 3, 2 and 4 (each within the scatter of the next).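

Chloro in place of methyl gives a 1.0-fold higher number from compound 3 to compound 4 (0.02 log units; within the scatter), and chloro in place of bromo gives a 1.0-fold higher number from compound 2 to compound 4 (0.01 log units; within the scatter), so in this assay all three groups para to the allyloxy group give numbers that stand level, and the earlier match between bromo and methyl now extends to a third group. Among these compounds, compound 4 also allows the first clean reading at the oxygen, since the chloro stays fixed while allyl takes the place of hydrogen: that change gives a 4.7-fold higher number from compound 1 to compound 4 (0.67 log units; beyond the scatter), a modest step beyond the scatter, showing that the gap between compound 1 and the allyl compounds belongs to the oxygen substituent and not to the chloro. No measurement here offers an explanation for either the flat result at the ring position or the step at the oxygen.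

Going by these compounds, the three groups at the ring position are all single small substituents, so it remains open whether a quite different group there, such as an amine or a carboxylic acid, would shift the number. The oxygen step also rests on one pair with chloro, leaving open whether it holds with bromo or methyl and how a longer chain in place of allyl would read.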